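A larger group on the carbonyl of compound 2

The source may report more compounds than this note shows. Statements on the series, on what has been measured and on what is new or still open speak of the compounds shown alone.

Values measured in a physicochemical assay for lipophilicity, measured as octanol-water partition, at pH 7.4; on this read-out higher numbers stand for higher lipophilicity and lower numbers for lower lipophilicity:
- compound 1 `Cc1ccc2[nH]c(C(=O)N[C@H]3CCN(S(=O)(=O)c4ccccc4)C[C@@H]3C(=O)NCCN(C)C)cc2c1`: 2.2
- compound 2 `Cc1csc(C(=O)N[C@H]2CN(S(=O)(=O)c3ccccc3)C[C@@H]2C(=O)N[C@H]2CCCNC2)n1`: 0.1
- compound 3 `Cc1oc(-c2ccc(C(F)(F)F)cc2)nc1C(=O)N[C@H]1CN(S(=O)(=O)c2ccccc2)C[C@@H]1C(=O)N[C@H]1CCCNC1`: 2.3

Of these three, compound 2 stands lowest, at 0.1. Compound 1 and compound 3 both lie above it, each by more than the usual scatter, while their own two values lie within the scatter of each other.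

Compound 4 `O=C(N[C@H]1CN(S(=O)(=O)c2ccccc2)C[C@@H]1C(=O)N[C@H]1CCCNC1)c1cc(-c2ccccc2Cl)on1` has not yet been measured in this assay. It differs from compound 2 in one place: a group of 12 heavy atoms (9 carbon, 1 nitrogen, 1 oxygen, 1 chlorine; one five-membered aromatic ring with 2 hetero atoms, one six-membered aromatic ring of carbon only) in place of a group of 6 heavy atoms (4 carbon, 1 nitrogen, 1 sulfur; one five-membered aromatic ring with 2 hetero atoms), on a carbonyl carbon. The 4-methyl-1,3-thiazol-2-yl group leaves, and a larger group enters on the same carbonyl carbon, with a five-membered aromatic ring and a six-membered aromatic ring of carbon only.

Among the measured compounds shown here, no measured pair isolates this change, so the expectation rests on indirect evidence. The closest guide is compound 3, whose group on that carbonyl carbon also includes a six-membered aromatic ring of carbon only, and which gives 2.3. An upward move beyond the scatter is therefore expected, an estimated a number 1.60 log units higher from compound 2 to compound 4 (beyond the scatter). The estimate for compound 4 is 1.7, with an expected range from 1.1 to 2.4.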

Compound 4, distribution coefficient: 1.9
Estimate against measurement, compound 4: 0.20 log units below; low and high end bracket the measured number.
By their numbers in this assay, from the lowest: compound 2; then compounds 4, 1 and 3 (each within the scatter of the next, the first and the last beyond it).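

In this assay, among the compounds shown here, exchanging the 4-methyl-1,3-thiazol-2-yl group for the larger group on the same carbonyl carbon gives a number 1.80 log units higher from compound 2 to compound 4 (beyond the scatter), the first step in this set that isolates a single place. It shows that this carbonyl carbon alone can carry a large change in this read-out while the rest of the molecule stays fixed, and that the change comes with no difference in the counted hydrogen-bond donors, hydrogen-bond acceptors or net charge of the two groups, only in heavy atoms and the added six-membered aromatic ring of carbon only. No independent measurement is at hand that would account for the size of this step.

The chlorine, the six-membered aromatic ring and the exchange of one five-membered aromatic ring for another all enter together, so the step cannot be divided among them. On these data alone, it also remains open how the read-out would respond to an amine or a carboxylic acid in place of the chlorine, or to a plain phenyl group on the same carbonyl carbon.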